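This account rests on a few compounds, and the source may have more. Where it says the series, first, only, none or still open, it means among the compounds named here.

Measured so far in an assay on microsomes for inhibition of Amine oxidase [flavin-containing] B (Homo sapiens), read by fluorescence and spectrophotometry, with a stated time of 20 min; on this read-out lower numbers stand for stronger inhibition and higher numbers for weaker inhibition:
- compound 1 `O=c1ccoc2ccc(OCc3ccc(Br)cc3)cc12`, value 3.3 nM
- compound 2 `Cc1ccc(COc2ccc3occc(=O)c3c2)cc1`, value 6 nM

Compound 2 holds the higher of the two numbers shown in this assay, the only comparison being to compound 1, a step of a 1.8-fold higher number from compound 1 to compound 2 (0.26 log units; within the scatter); with two compounds so close, no order between them can be claimed.

The next compound, compound 3 `N#Cc1ccc(COc2ccc3occc(=O)c3c2)cc1`, continues the variation of the substituent on the pendant aromatic ring: cyano in place of methyl on an aromatic carbon. Among the measured compounds shown here, the only measured step that bears on it is the one from compound 1 to compound 2, which exchanged bromo for methyl at the same position and produced only a 1.8-fold higher number from compound 1 to compound 2 (0.26 log units; within the scatter). That step says the pendant aromatic ring tolerates a change of substituent without leaving the scatter; the cyano group, however, brings in a hydrogen-bond acceptor and a triple bond outside aromatic rings, which neither measured compound carries, so nothing in the data anchors its effect directly. In this assay compound 3 is therefore expected to stay near compound 2, with a step of a 1.3-fold higher number from compound 2 to compound 3 (0.12 log units; within the scatter). The estimate for compound 3 is 8 nM, ranging from 2.5 nM to 25 nM.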

Compound 3, half-maximal inhibitory concentration: 22 nM
The estimate for compound 3 lay 2.8-fold (0.44 log units) below the measured number, and the stated range covers the measured number.
By their numbers in this assay, from the lowest: compounds 1 and 2 (each within the scatter of the next); then compound 3.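

In this assay, the aromatic carbon para to a large group proves sensitive to the choice of substituent: cyano in place of methyl gives a 3.7-fold higher number from compound 2 to compound 3 (0.56 log units; beyond the scatter), and cyano in place of bromo gives a 6.7-fold higher number from compound 1 to compound 3 (0.82 log units; beyond the scatter), both modest, whereas the exchange of bromo for methyl stayed within the scatter. With both steps beyond the scatter, compound 3 is the weakest inhibitor of the three, so the tolerance seen between compound 1 and compound 2 does not extend to cyano, the only substituent here with a triple bond outside aromatic rings and a hydrogen-bond acceptor. No supporting measurement is available to explain why cyano parts from bromo and methyl at this position.

With only bromo, methyl and cyano at this place, the series cannot show whether the higher number goes with the hydrogen-bond acceptor, the triple bond or the second heavy atom of the group. Going by these compounds, a methoxy group or a primary amide at the same place would help separate these features, and how cyano behaves elsewhere on the pendant ring remains open.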